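The source may report more compounds than this note shows. Statements on the series, on what has been measured and on what is new or still open speak of the compounds shown alone.

In an ADME assay on L6 cells (Rattus norvegicus) for cytotoxicity, read by fluorescence and resazurin assay, with a stated time of 72 h (on this read-out higher numbers stand for lower toxicity in this test and lower numbers for higher toxicity in this test), the compounds measured so far read as follows:
Compound 1 `Clc1ccc(-c2c[nH]cc2C(c2ccc(Cl)cc2Cl)n2ccnc2)cc1` gives 9610 nM
Compound 2 `Clc1ccc(C(c2c[nH]cc2-c2ccc(Cl)c(Cl)c2)n2ccnc2)c(Cl)c1` gives 3640 nM

Compound 2 holds the lower of these two numbers, and compound 1 stands above it. Next comes compound 3 `Clc1ccc(-c2c[nH]cc2C(c2ccc(Cl)cc2Cl)n2ccnc2)c(Cl)c1` with 2,4-dichlorophenyl in place of 3,4-dichlorophenyl on an aromatic carbon of a five-membered aromatic ring with 1 nitrogen. The change is 2,4-dichlorophenyl in place of 3,4-dichlorophenyl on an aromatic carbon and the two have the same atoms, joined differently.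

Among the compounds with values here, only one measured step bears on this: a 2.6-fold lower number from compound 1 to compound 2 (0.42 log units; beyond the scatter) which is modest and sets chloro in place of hydrogen on an aromatic carbon. Within the data shown here, no measured step exchanges one dichlorophenyl for the other, so the direction is uncertain. In this assay the expected step is a 1.4-fold higher number from compound 2 to compound 3 (0.14 log units; within the scatter) and thus none beyond the scatter. The estimated value for compound 3 is 5000 nM (expected range 2000 nM to 12000 nM).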

Compound 3, half-maximal cytotoxic concentration: 9860 nM
For compound 3 the middle estimate is 2.0-fold (0.29 log units) below the measured one; the range from low to high includes it.
By their numbers in this assay, from the lowest: compound 2; then compounds 1 and 3 (each within the scatter of the next).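

Swapping 3,4-dichlorophenyl for 2,4-dichlorophenyl keeps the same atoms yet gives a 2.7-fold higher number from compound 2 to compound 3 (0.43 log units; beyond the scatter), so at this position the arrangement of the two chlorines alone moves the number, here towards lower toxicity in this test. The earlier compounds shown here showed only that adding a chloro could lower the number, as in a 2.6-fold lower number from compound 1 to compound 2 (0.42 log units; beyond the scatter). The same kind of change now gives a 1.0-fold higher number from compound 1 to compound 3 (0.01 log units; within the scatter), so adding a chloro to the aryl group of compound 1 does not lower the number in every case: the outcome differs between compound 2 and compound 3.

Nothing given here accounts for this difference between the two chlorine arrangements. On these data alone, it also remains open whether a methoxy or a trifluoromethyl group in place of the added chloro would follow compound 2 or compound 3.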